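Swapping the Halogenated Phenyl on the Styryl Arm

The source may hold more compounds than are shown below. What is called first, only, known or untested is meant among the compounds shown, and "the series" means these compounds.

Compound 1, `NCc1nnc(-c2cc(S(N)(=O)=O)c(SCc3ccccc3)cc2Cl)o1`: in a functional assay on HeLa cells (Homo sapiens) for cytotoxicity, read by MTT assay, with a stated time of 72 h (on this read-out higher numbers stand for weaker inhibition and lower numbers for stronger inhibition), compound 1 gives 490000 nM.
Compound 2, `NS(=O)(=O)c1cc(-c2nnc(/C=C/c3ccccc3)o2)c(Cl)cc1SCc1ccccc1`: in this assay compound 2 gives 14000 nM.
Compound 3, `NS(=O)(=O)c1cc(-c2nnc(/C=C/c3cccc(Cl)c3)o2)c(Cl)cc1SCc1ccccc1`: in this assay compound 3 gives 16000 nM.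

Compound 3 stands second highest of the three numbers. Its nearest neighbour is compound 2, from which it is separated only by a 1.1-fold higher number from compound 2 to compound 3 (0.06 log units; within the scatter), and its furthest is compound 1, separated by a 31-fold lower number from compound 1 to compound 3 (1.49 log units; beyond the scatter).

Compound 4, `NS(=O)(=O)c1cc(-c2nnc(/C=C/c3ccc(Br)cc3)o2)c(Cl)cc1SCc1ccccc1`, differs from compound 3 in one place: 4-bromophenyl in place of 3-chlorophenyl on a double-bonded chain carbon bound to a double-bonded chain carbon. The measured step that bears most directly on this change is a 1.1-fold higher number from compound 2 to compound 3 (0.06 log units; within the scatter), which shows that adding a chlorine to the phenyl on the ethenyl chain left the number where it was. The large steps of a 35-fold lower number from compound 1 to compound 2 (1.54 log units; beyond the scatter) and a 31-fold lower number from compound 1 to compound 3 (1.49 log units; beyond the scatter) concern the replacement of aminomethyl by the whole ethenyl-phenyl arm and say nothing about which halogen sits on that phenyl. Exchanging one halogenated phenyl for another is therefore expected to give no step beyond the scatter, a 1.1-fold lower number from compound 3 to compound 4 (0.03 log units; within the scatter). For compound 4 in this assay the estimate is 15000 nM, expected to lie between 6000 nM and 40000 nM.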

Compound 4, half-maximal inhibitory concentration: 29000 nM
Beside the measured number, compound 4's estimate is 1.9-fold (0.29 log units) below it; measured number inside the range.
By their numbers in this assay, from the lowest: compounds 2, 3 and 4 (each within the scatter of the next, the first and the last beyond it); then compound 1.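

Exchanging 3-chlorophenyl for 4-bromophenyl on the ethenyl chain gives a 1.8-fold higher number from compound 3 to compound 4 (0.26 log units; within the scatter) in this assay, so this swap does not separate the two halogenated compounds. Among the compounds shown here, the bromine does show something the chlorine did not: adding it to the unsubstituted phenyl gives a 2.1-fold higher number from compound 2 to compound 4 (0.32 log units; beyond the scatter), a modest step and the first halogen step on this phenyl to pass the scatter, while a 17-fold lower number from compound 1 to compound 4 (1.23 log units; beyond the scatter) shows that the arm keeps a large step over aminomethyl with 4-bromophenyl in place. No measurement here gives a reason for these differences.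

The halogen and its place on the phenyl change together in this pair, so 4-chlorophenyl and 3-bromophenyl on the same chain would be needed to tell the two apart. As far as these compounds go, whether an amine or a carboxylic acid on that phenyl would shift the number also remains open.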